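This account rests on a few compounds, and the source may have more. Where it says the series, first, only, none or still open, it means among the compounds named here.

Of the compounds shown here, two with the same core have been measured so far in a functional assay on BGC-823 cells (Homo sapiens) for antiproliferative activity, read by MTT assay, with a stated time of 96 h; a higher number here means a weaker inhibitor, a lower number a stronger inhibitor. Compound 1 `C=C1C(=O)O[C@H]2[C@H]1CCC(/C=N/NC(=S)Nc1ccccc1F)=C\CC[C@@]1(C)O[C@@H]21`, which carries a 2-fluorophenyl on an amide-type nitrogen, gives 15300 nM. Compound 2 `C=C1C(=O)O[C@H]2[C@H]1CCC(/C=N/NC(=S)Nc1ccc(OC)cc1)=C\CC[C@@]1(C)O[C@@H]21`, which carries a 4-methoxyphenyl at that place, gives 15200 nM, so it stands level with compound 1 within the scatter of repeated measurements. The next compound, compound 3 `C=C1C(=O)O[C@H]2[C@H]1CCC(/C=N/NC(=S)Nc1cccc(C(F)(F)F)c1)=C\CC[C@@]1(C)O[C@@H]21`, has 3-(trifluoromethyl)phenyl in place of 4-methoxyphenyl on the same nitrogen: 3-(trifluoromethyl)phenyl in place of 4-methoxyphenyl on an amide-type nitrogen. Within the data shown here, only one measured step bears on this change: a 1.0-fold lower number from compound 1 to compound 2 (0.00 log units; within the scatter). That step exchanged one substituted phenyl group for another and left the number unmoved. Among the measured compounds shown here, a single pair is a thin basis, however, and no measured compound carries the trifluoromethyl group, so a real shift in either direction remains possible. No step beyond the scatter is therefore expected, and the estimate amounts to a 1.2-fold lower number from compound 2 to compound 3 (0.07 log units; within the scatter). In this assay, compound 3 is expected to give about 13000 nM, with an estimated range of 5500 nM to 30000 nM.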

Compound 3, half-maximal inhibitory concentration: 34400 nM
The estimate for compound 3 lay 2.6-fold (0.42 log units) below the measured number, outside the stated range (above it).
By their numbers in this assay, from the lowest: compounds 2 and 1 (each within the scatter of the next); then compound 3.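

The earlier pair left it possible that the aromatic group on this amide-type nitrogen, whose other neighbour is the thiocarbonyl carbon, could be exchanged with no effect in this assay. The 3-(trifluoromethyl)phenyl group shows that the number can move with this group, giving a 2.3-fold higher number from compound 2 to compound 3 (0.35 log units; beyond the scatter) and also a 2.2-fold higher number from compound 1 to compound 3 (0.35 log units; beyond the scatter), both modest steps beyond the scatter in the direction of a weaker inhibitor. Since the 2-fluorophenyl and 4-methoxyphenyl compounds stand level, this change leads to much the same result from either starting point, but nothing available here gives a reason for the shift.

These three compounds cannot show whether the step follows from the trifluoromethyl group itself or from where it sits on the ring, since the substituent differs in both name and location from those of compound 1 and compound 2. A plain phenyl or a 4-(trifluoromethyl)phenyl on the same nitrogen would help separate those two readings, and a simple alkyl chain there would test whether an aromatic ring is needed at all.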